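Compound 3 to compound 4: removing one methoxy

This account rests on a few compounds, and the source may have more. Where it says the series, first, only, none or still open, it means among the compounds named here.

compound 1 `COc1cc(OC)c(OC)cc1/C=C/C(=O)c1ccc(Cl)cc1` gives 2.3 ug/mL
compound 2 `COc1cc(OC)c(OC)cc1/C=C/C(=O)c1ccc(-c2c[nH]cn2)cc1` gives 2.48 ug/mL
compound 3 `COc1cc(C(=O)/C=C/c2cc(OC)c(OC)cc2OC)ccc1O` gives 2.16 ug/mL

These three values come from a functional assay on cells (Erythrocyte, Rattus norvegicus) for inhibition, read by hemolysis, with a stated time of 1 h (a lower number here means a stronger inhibitor, a higher number a weaker inhibitor), and they lie close together. Compound 3 stands within the scatter of both compound 1 and compound 2, so no order can be drawn among the three. Compound 4 `COc1cc(OC)c(OC)cc1/C=C/C(=O)c1ccc(O)cc1` has not yet been measured and differs from compound 3 in one place. The change is hydrogen in place of methoxy on an aromatic carbon and it amounts to hydrogen in place of methoxy on an aromatic carbon, ortho to a hydroxy group and meta to a large group.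

Among the measured compounds shown here, only one measured step bears on this, and only indirectly, since it is a different change: 1H-imidazol-4-yl in place of chloro on an aromatic carbon gives a 1.1-fold higher number from compound 1 to compound 2 (0.03 log units; within the scatter) in the read-out, which is within the scatter. For the measured compounds named here, no measured step removes a methoxy. Compound 3 at 2.16 ug/mL is therefore the starting point, and no step beyond the scatter is expected in this assay for this change. The expected step is a 1.1-fold higher number from compound 3 to compound 4 (0.03 log units; within the scatter) and it would stay within the scatter. For compound 4 the estimated value is 2.3 ug/mL with an expected range of 1.3 ug/mL to 4 ug/mL around it.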

Compound 4, half-maximal inhibitory concentration: 2.29 ug/mL
Compound 4: the middle estimate sits 1.0-fold (0.00 log units) above what was measured; the range from low to high includes it.
By their numbers in this assay, from the lowest: compounds 3, 4, 1 and 2 (each within the scatter of the next).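

In this assay, hydrogen in place of methoxy, ortho to a hydroxy group and meta to a large group, gives a 1.1-fold higher number from compound 3 to compound 4 (0.03 log units; within the scatter), so this methoxy makes no difference that the read-out can resolve. Among the compounds shown here, compound 4 also shows that a lone hydroxy group cannot be told apart from the other groups carried by the earlier compounds: hydroxy in place of chloro gives a 1.0-fold lower number from compound 1 to compound 4 (0.00 log units; within the scatter), and hydroxy in place of 1H-imidazol-4-yl gives a 1.1-fold lower number from compound 2 to compound 4 (0.03 log units; within the scatter), so all four compounds now lie within the scatter of one another and the flat picture extends to a small hydroxy group as well as a chloro and a ring. Nothing available gives a reason for this flat picture.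

The compounds shown leave open whether a carboxylic acid, an amine or a longer chain at this place would move the number beyond the scatter. They also leave open what the trimethoxy-substituted side of the shared core and its carbonyl contribute, since all four compounds keep both unchanged.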